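Methyl in Place of Bromo: What Compound 3 Might Tolerate

A few compounds are considered here, and "the series" means these few. Any claim that something is new, unique, unknown or untested is made for them only; others in the source may bear on it.

Compound 1 `O=C(COc1cccc2ccccc12)N/N=C/c1ccc(Br)cc1` was examined in an ADME assay on HEL cells (Homo sapiens) for cytotoxicity (a lower number here means that less compound is tolerated, a higher number that more compound is tolerated), alongside compound 2 `C/C(=N\NC(=O)COc1cccc2ccccc12)c1ccccc1O`. In this assay compound 1 gives only a limit of the assay, > 100 ug/mL. Compound 1 therefore stands at the limit of > 100 ug/mL in this assay, at which 1 of the 2 values shown sits. In this assay compound 2 gives 20 ug/mL, a number inside the measured range. Going by the values given here, no step between these two compounds is given, so only their two values speak for themselves.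

Compound 3 `Cc1ccc(/C=N/NC(=O)COc2cccc3ccccc23)cc1` has not yet been measured. It differs from compound 1 in one place: methyl in place of bromo on an aromatic carbon. Among the compounds with values here, no measured step in this assay tells how such a change acts here, and the account expects none beyond the scatter, with compound 1 sitting at its limit. For compound 3 in this assay the expected value is 100 ug/mL, within a range from 50 ug/mL to 200 ug/mL. The step this estimate implies is a number no higher from compound 1 to compound 3 (the limit leaves the size open), an expectation only.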

Compound 3, minimum cytotoxic concentration: 20 ug/mL
Compound 3: the middle estimate sits 5.0-fold (0.70 log units) above what was measured; the whole stated range lies above it.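

Going by these compounds alone, the change from bromo to methyl, para to a large group, is the first single change on the shared core that can be read in this assay, and it gives an at least 5.0-fold lower number from compound 1 to compound 3 (0.69 log units; beyond the scatter). This position is therefore not indifferent to what it carries, even though the two groups match in every count computed for them. As far as these compounds go, how far the step reaches stays open because compound 1 sits at a limit of the assay: the limit of > 100 ug/mL in this assay, at which 1 of the 3 values shown sits.

The compounds shown leave open how chloro, methoxy, an amine or a carboxylic acid would fare at this position, and so whether bromo or methyl is the unusual case. They also leave open whether a longer chain in place of methyl would carry the number lower still or bring it back up.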